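The source may hold more compounds than are shown below. What is called first, only, known or untested is meant among the compounds shown, and "the series" means these compounds.

Compound 1 `COc1nc(C(C)(C)C)ccc1[C@@H](c1ccccc1)[C@@](O)(CCN(C)C)c1cccc2ccccc12` and compound 2 `COc1nc(-c2ccsc2)ccc1[C@@H](c1ccccc1)[C@@](O)(CCN(C)C)c1cccc2ccccc12` share the same core and differ only in one aromatic substituent. In a toxicity assay on HeLa cells (Homo sapiens) for cytotoxicity (a lower number here means that less compound is tolerated, a higher number that more compound is tolerated), compound 1 gives > 64 ug/mL, which is a limit of the assay rather than a number. In this assay compound 2 gives > 64 ug/mL, again a limit. The step that the two limits leave unreadable from compound 1 to compound 2 therefore cannot be read in size. Compound 2 thus stands at the limit of > 64 ug/mL in this assay, at which 2 of the 2 values shown sit, with nothing more said about it by the numbers shown. Compound 3 `COc1nc(-c2ccncc2)ccc1[C@@H](c1ccccc1)[C@@](O)(CCN(C)C)c1cccc2ccccc12` differs from compound 2 by pyridin-4-yl in place of thiophen-3-yl on an aromatic carbon. Among the measured compounds shown here, the only measured step does not bear readably on this change, so no direction can be drawn from it. Because compound 2 stands at the limit of > 64 ug/mL in this assay, at which 2 of the 2 values shown sit, the step that the limit leaves unreadable from compound 2 to compound 3 is expected to stay within the scatter. Compound 3 is estimated at 80 ug/mL, with a range from 32 ug/mL to 200 ug/mL.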

Compound 3, half-maximal cytotoxic concentration: 9.6 ug/mL
Estimate against measurement, compound 3: 8.3-fold (0.92 log units) above; the measured number lies below the stated range.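

Among the compounds shown here, with pyridin-4-yl on this aromatic carbon next to the ring nitrogen, this assay gives a readable step for the first time: there is an at least 6.6-fold lower number from compound 2 to compound 3 (0.82 log units; beyond the scatter) and also an at least 6.6-fold lower number from compound 1 to compound 3 (0.82 log units; beyond the scatter) on the same change of group. What this position carries can therefore lower the number, and pyridin-4-yl stands apart here from both thiophen-3-yl and tert-butyl. The earlier step between those two groups cannot be read, and compounds 1 and 2 both stop at a limit: the limit of > 64 ug/mL in this assay, at which 2 of the 3 values shown sit.

Going by these compounds, both new steps start from a limit and their full size stays open. The compounds shown also leave open whether the drop follows the nitrogen of pyridin-4-yl or its six-membered ring, and how a plain phenyl ring or a carboxylic acid at this position would read.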